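Fluoro for methoxy on the (4-methoxyphenyl)sulfanyl group

The source may report more compounds than this note shows. Statements on the series, on what has been measured and on what is new or still open speak of the compounds shown alone.

Compound 1 `Nc1cc(N)c2nc(-c3ccccc3)c(Oc3ccc(Cl)c(Cl)c3)nc2c1` gives 85100 nM in a functional assay on HOP-62 cells (Homo sapiens) for inhibition, read by sulforhodamine B assay, with a stated time of 48 h; on this read-out higher numbers stand for lower toxicity in this test and lower numbers for higher toxicity in this test. Compound 2 `COc1ccc(Sc2nc3cc(N)cc(N)c3nc2-c2ccccc2)cc1` sits at the limit of the assay, < 100000 nM, so only a bound is known for it. The step that the limit leaves unreadable from compound 1 to compound 2 is therefore not readable, as the limit of < 100000 nM in this assay, at which 1 of the 2 values shown sits, shows. Compound 3 `Nc1cc(N)c2nc(-c3ccccc3)c(Sc3ccc(F)cc3)nc2c1` differs from compound 2 by fluoro in place of methoxy on an aromatic carbon. For the measured compounds named here, no measured step resolves a change of this kind, so the expectation is for no shift beyond the scatter, a step that the limit leaves unreadable from compound 2 to compound 3, estimated. Compound 3 is accordingly expected near 70000 nM, within 20000 nM to 100000 nM.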

Compound 3, concentration lethal to 50% of the cells: 70800 nM
Compound 3: middle estimate off by 1.0-fold (0.00 log units), on the low side, within the range that was stated.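

In this assay, for the compounds shown here, compound 3 gives the first readable number for a sulfanyl-linked aryl group at this position, and the exchange of 3,4-dichlorophenoxy for (4-fluorophenyl)sulfanyl is a 1.2-fold lower number from compound 1 to compound 3 (0.08 log units; within the scatter). This position therefore takes either of these two groups with no shift beyond the scatter. The steps that involve compound 2 cannot be read: the limit of < 100000 nM in this assay, at which 1 of the 3 values shown sits.

As far as these compounds go, whether fluoro and methoxy differ on this aromatic carbon stays open. Also open, from the compounds shown here alone, is what an amine or a carboxylic acid in the same place would give.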